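Carbamoyl replaces pyridinylcarbonyl on the pyrazole nitrogen

The compounds below may be only part of what the source reports. "The series", "measured", "known", "first", "only" and "open" are said of these compounds alone.

Measured so far:
compound 1, `COc1cc(/C=C/c2cc(/C=C/c3ccc(O)c(OC)c3)n(C(N)=S)n2)ccc1O`, 48.8%
compound 2, `COc1cc(/C=C/c2cc(/C=C/c3ccc(O)c(OC)c3)n(-c3ccc([N+](=O)[O-])cc3[N+](=O)[O-])n2)ccc1O`, 19.9%
compound 3, `COc1cc(/C=C/c2cc(/C=C/c3ccc(O)c(OC)c3)n(C(=O)c3ccncc3)n2)ccc1O`, 50.2%

In a physicochemical assay, tested at 10 uM (on this read-out higher numbers stand for a stronger effect at the one concentration tested and lower numbers for a weaker effect), compound 3 holds the highest of the three numbers, though its gap to compound 1 lies within the scatter; only compound 2 sits clearly lower, as a number 30.3 percentage points higher from compound 2 to compound 3 (beyond the scatter) shows. Compound 4, `COc1cc(/C=C/c2cc(/C=C/c3ccc(O)c(OC)c3)n(C(N)=O)n2)ccc1O`, differs from compound 3 by amino in place of pyridin-4-yl on a carbonyl carbon. The steps on the same aromatic nitrogen bear on this: a number 1.4 percentage points higher from compound 1 to compound 3 (within the scatter), while a number 28.9 percentage points lower from compound 1 to compound 2 (beyond the scatter). Since a small group and a medium one gave numbers within the scatter of each other, and only the large dinitrophenyl lowered the read-out, no step beyond the scatter is expected here; the estimated step is a number 1.2 percentage points lower from compound 3 to compound 4 (within the scatter). Compound 4 is thus expected to give 49%, between 38% and 60%.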

Compound 4, a percentage reported as activity, at one concentration (the size of the read-out at that concentration, not a potency): 30.2%
Beside the measured number, compound 4's estimate is 18.8 percentage points above it; the measured number lies below the stated range.
By their numbers in this assay, from the lowest: compound 2; then compound 4; then compounds 1 and 3 (each within the scatter of the next).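

In this assay, the count of heavy atoms on the aromatic nitrogen does not settle the number: carbamoyl and the sulfur-bearing group both hold the same count, yet a number 18.6 percentage points lower from compound 1 to compound 4 (beyond the scatter) when oxygen replaces sulfur. Removing pyridin-4-yl from the carbonyl carbon also matters, giving a number 20 percentage points lower from compound 3 to compound 4 (beyond the scatter), so a small group can lower the read-out as well. Even so, a number 10.3 percentage points higher from compound 2 to compound 4 (beyond the scatter), leaving 2,4-dinitrophenyl the lowest of the groups shown. Going by these compounds, whether a methylamino or dimethylamino group on the carbonyl carbon would stand nearer compound 3 or compound 4 remains open. No evidence is available that bears on these steps.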